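Acetyl in place of chloro on the phenoxy ring

The compounds below may be only part of what the source reports. "The series", "measured", "known", "first", "only" and "open" are said of these compounds alone.

In a functional assay on HMEC-1 cells (Homo sapiens) for antiproliferative activity, read by cell counting, with a stated time of 4 days (a higher number here means a weaker inhibitor, a lower number a stronger inhibitor), compound 1 (`CC(Nc1ccccc1Oc1cccc(F)c1)=C1C(=O)CC(c2ccccc2)CC1=O`) gives 360 nM and compound 2 (`CC(Nc1ccccc1Oc1ccc(Cl)cc1)=C1C(=O)CC(c2ccccc2)CC1=O`) gives 260 nM on the same cells. Among the compounds with values here, the only measured step is a 1.4-fold lower number from compound 1 to compound 2 (0.14 log units; within the scatter) and it lies within the scatter, so compound 2 stands level with compound 1, the only other compound measured.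

Compound 3 (`CC(=O)c1ccc(Oc2ccccc2NC(C)=C2C(=O)CC(c3ccccc3)CC2=O)cc1`) keeps the rest of compound 2 but carries acetyl in place of chloro on an aromatic carbon, para to a large group (acetyl in place of chloro on an aromatic carbon). Within the data shown here, the single measured step bears on this change only loosely. Among the measured compounds shown here, it also alters the substituted phenyl on the oxygen, but it involves no acetyl, and no measured compound carries that group. With that one small step as the guide, no change beyond the scatter is expected in this assay in either direction. The estimated step is a 1.3-fold higher number from compound 2 to compound 3 (0.13 log units; within the scatter) and it rests on very little evidence. For compound 3 the estimated value is 350 nM with an expected range from 120 nM to 1000 nM in this cell test.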

Compound 3, half-maximal inhibitory concentration: 180 nM
Estimate against measurement, compound 3: 1.9-fold (0.29 log units) above; the measured number falls inside the stated range.
By their numbers in this assay, from the lowest: compounds 3, 2 and 1 (each within the scatter of the next).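

In this assay, the change from 4-chlorophenoxy to 4-acetylphenoxy gives a 1.4-fold lower number from compound 2 to compound 3 (0.16 log units; within the scatter), so on this aromatic carbon, para to a large group, a chloro of 1 heavy atom gives way to an acetyl of 3 heavy atoms, with a double bond outside aromatic rings and a hydrogen-bond acceptor, without a step beyond the scatter. The wider exchange on the oxygen gives a 2.0-fold lower number from compound 1 to compound 3 (0.30 log units; within the scatter), which also stays within the scatter, so the 3-fluorophenyl, 4-chlorophenyl and 4-acetylphenyl groups stand level with one another in this cell test. The data offer no independent measurement that bears on this result.

The compounds shown leave open whether an amine or a carboxylic acid on this same aromatic carbon would stay level with these three or give a step beyond the scatter. They also leave open whether an acetyl on another carbon of this ring would read the same, since every compound here carries its changed group on the one shared core.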